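Furan-thiophene pyridines: a methylphenyl for a chlorophenyl

The source may report more compounds than this note shows. Statements on the series, on what has been measured and on what is new or still open speak of the compounds shown alone.

Measured compounds:
compound 1 `Clc1ccc(-c2cc(-c3cccnc3)nc(-c3cccs3)c2)o1` gives 14600 nM
compound 2 `Clc1cccc(-c2cc(-c3ccc(Cl)o3)cc(-c3cccs3)n2)c1` gives 12800 nM

Two compounds share a core carrying a 5-chlorofuran-2-yl group and a thiophen-2-yl group. In a functional assay on HeLa cells (Homo sapiens) for cytotoxicity, in the presence of a further agent that is not named here (a lower number here means a stronger inhibitor, a higher number a weaker inhibitor), compound 1 gives 14600 nM. Compound 2 carries a 3-chlorophenyl group where compound 1 carries a pyridin-3-yl group, and in this assay compound 2 gives 12800 nM. The step of a 1.1-fold lower number from compound 1 to compound 2 (0.06 log units; within the scatter) is the only measured one, and it is within the scatter, so the two numbers cannot be ordered. Compound 2 is therefore not separated from compound 1.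

Compound 3 `Cc1ccc(-c2cc(-c3ccc(Cl)o3)cc(-c3cccs3)n2)cc1` is not yet measured. The change from compound 2 is 4-methylphenyl in place of 3-chlorophenyl on an aromatic carbon. For the measured compounds named here, no measured step exchanges one carbon-only six-membered aromatic ring for another of the same kind at this position; the single step available, from a pyridin-3-yl to a 3-chlorophenyl group, stayed within the scatter. On that basis no step beyond the scatter is expected in this assay, neither up nor down. The expectation for compound 3 is a step of a 1.0-fold higher number from compound 2 to compound 3 (0.01 log units; within the scatter). Compound 3 is estimated at 13000 nM, with a range from 5000 nM to 35000 nM.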

Compound 3, half-maximal inhibitory concentration: 16300 nM
Beside the measured number, compound 3's estimate is 1.3-fold (0.10 log units) below it; measured number inside the range.
By their numbers in this assay, from the lowest: compounds 2, 1 and 3 (each within the scatter of the next).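

In this assay, for the compounds shown here, the step of a 1.3-fold higher number from compound 2 to compound 3 (0.10 log units; within the scatter) is the first exchange of one carbon-only six-membered aromatic ring for another at this position, next to the ring nitrogen, and it stays within the scatter. With the step of a 1.1-fold higher number from compound 1 to compound 3 (0.05 log units; within the scatter) also within the scatter, pyridin-3-yl, 3-chlorophenyl and 4-methylphenyl are not separated here, so neither the substituent on the phenyl ring nor the ring nitrogen of the pyridin-3-yl group is tied to a measurable difference among these three compounds. No supporting measurement is available that would bear on this result.

The compounds shown leave open whether a group of a different kind at this position, such as an amine or a carboxylic acid on the phenyl ring, or a longer chain in place of the ring, would give a step beyond the scatter. On these data alone, all three compounds also keep the 5-chlorofuran-2-yl and thiophen-2-yl groups, so what a change at either of those two places would do in this assay remains unknown.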